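One More Fluoro on a Compound at the Limit

A few compounds are considered here, and "the series" means these few. Any claim that something is new, unique, unknown or untested is made for them only; others in the source may bear on it.

Compound 1 `Nc1nc(NCCNc2ncc(-c3ncc[nH]3)c(-c3ccc(Cl)cc3)n2)ccc1[N+](=O)[O-]` gives > 0.5 h 
Compound 2 `Nc1nc(NCCNc2ncc(-c3ncc[nH]3)c(-c3ccc(C(F)(F)F)cc3)n2)ccc1[N+](=O)[O-]` gives > 0.5 h 
Compound 3 `Nc1nc(NCCNc2ncc(-c3ncc[nH]3)c(-c3cc(F)ccc3F)n2)ccc1[N+](=O)[O-]` gives > 0.5 h 

These entries come from an ADME assay on microsomes from liver (Rattus norvegicus) for metabolic stability (a lower number here means that the compound disappears faster, a higher number that the compound lasts longer), and the read-out is a half-life. Compound 3 stands at > 0.5 h and this is a limit of the assay, not a number. The whole set looks the same, with the limit of > 0.5 h in this assay, at which 3 of the 3 values shown sit, as the only thing that can be said of its position.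

Compound 4 `Nc1nc(NCCNc2ncc(-c3ncc[nH]3)c(-c3cc(F)c(F)cc3F)n2)ccc1[N+](=O)[O-]` differs by one small change: fluoro in place of hydrogen on an aromatic carbon (2,5-difluorophenyl to 2,4,5-trifluorophenyl). Three measured steps swap groups on this same aromatic ring: a step that the two limits leave unreadable from compound 1 to compound 2 and a step that the two limits leave unreadable from compound 1 to compound 3 and a step that the two limits leave unreadable from compound 2 to compound 3 (none has a readable size). They therefore offer no size to carry over, so no shift beyond the usual scatter is expected in this assay and no direction can be favoured. The expected change is a step that the limit leaves unreadable from compound 3 to compound 4 (an estimate only). The estimated half-life of compound 4 is 0.8 h (expected range 0.5 h to 2 h) and the assay may well report only a limit again.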

Compound 4, half-life: > 0.5 h
Compound 4: a limit, no number; the forecaster's own chance of this, stated with the estimate: 85%; the middle value lies beyond the limit too.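

In this assay compound 4 gives > 0.5 h, which is a limit and not a number. For the compounds shown here, no step from compound 1, compound 2 or compound 3 to compound 4 can therefore be read. What stays open is how long each compound actually lasts, and whether changing the aromatic ring groups alters that at all: the limit of > 0.5 h in this assay, at which 4 of the 4 values shown sit.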